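The compounds below may be only part of what the source reports. "The series", "measured", "known", "first", "only" and "open" are said of these compounds alone.

Measured compounds:
- compound 1, `CC(C)=CCC[C@H](C)c1ccc(C)cc1O`: > 20000 nM
- compound 2, `CC(C)=CCC[C@H](C)c1ccc(C)c2c1OCN(CC1CCNCC1)C2`: 8100 nM
- compound 3, `CC(C)=CCC[C@H](C)c1ccc(C)c(CNCCCCCO)c1O`: 7600 nM

The account follows a ring-bearing phenol series tested in a functional assay on MCF7 cells (Homo sapiens) for inhibition, read by MTT assay, with a stated time of 72 h; a lower number here means a stronger inhibitor, a higher number a weaker inhibitor. Compound 1 is the simplest member of the series; in this assay compound 1 reaches only the assay limit of > 20000 nM. Compound 3 carries the ((5-hydroxypentyl)amino)methyl group and gives 7600 nM in this assay, which yields an at least 2.6-fold lower number from compound 1 to compound 3 (0.42 log units; beyond the scatter). Compound 2, the cyclised analogue, gives 8100 nM in this assay; it stands highest of the two numbers available, but its gap to compound 3 lies within the scatter, so the two cannot be ordered.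

Compound 4, `CCOC(CCN1COc2c([C@@H](C)CCC=C(C)C)ccc(C)c2C1)OCC`, has not yet been measured. It differs from compound 2 by 2,2-diethoxyethyl in place of piperidin-4-yl on a saturated chain carbon bound to an amine nitrogen in a ring. For the measured compounds named here, no measured step covers this kind of exchange: the only measured step, that from compound 1 to compound 3, concerns a different place and a different group, so it gives no direction for compound 4. Compound 4 is therefore expected to stay near compound 2, with a step of a 1.2-fold higher number from compound 2 to compound 4 (0.09 log units; within the scatter) expected. Compound 4 is estimated at 10000 nM, with a range from 4000 nM to 25000 nM.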

Compound 4, half-maximal inhibitory concentration: 13200 nM
Estimate against measurement, compound 4: 1.3-fold (0.12 log units) below; the range from low to high includes it.
By their numbers in this assay, from the lowest: compounds 3, 2 and 4 (each within the scatter of the next). At a limit, above all of these: compound 1.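

In this assay, for the compounds shown here, the exchange on a saturated chain carbon bound to an amine nitrogen in a ring gives a 1.6-fold higher number from compound 2 to compound 4 (0.21 log units; within the scatter), the first measured step at this position. Piperidin-4-yl, with its six-membered ring and one hydrogen-bond donor, can thus give way to 2,2-diethoxyethyl, with no ring and no donor, without a change that stands clear of the scatter. Nothing measured here bears on why this exchange leaves the number within the scatter.

The compounds shown leave open whether a carboxylic acid, a primary amine or a longer alkyl chain in place of 2,2-diethoxyethyl would move the number beyond the scatter. They also leave open how a cyclised analogue carrying a 5-hydroxypentyl chain on the ring nitrogen would compare with compound 3.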